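Swapping dimethylamino for methylcarbamoyl in a cytotoxicity series

This account rests on a few compounds, and the source may have more. Where it says the series, first, only, none or still open, it means among the compounds named here.

Compound 1 `O=C(O)c1ccc2c(c1)nc(-c1ccc(OCc3ccccc3-c3ccc(Cl)cc3)cc1)n2C1CCCCC1`: 25000 nM
Compound 2 `CN(C)S(=O)(=O)c1ccc(-c2ccc(Cl)cc2)c(COc2ccc(-c3nc4cc(C(=O)O)ccc4n3C3CCCCC3)cc2)c1`: 26000 nM
Compound 3 `CN(C)c1ccc(-c2ccc(Cl)cc2)c(COc2ccc(-c3nc4cc(C(=O)O)ccc4n3C3CCCCC3)cc2)c1`: 30000 nM

All three were tested in a functional assay on Huh-5-2 cells (Homo sapiens), read by MTT assay; on this read-out higher numbers stand for lower toxicity in this test and lower numbers for higher toxicity in this test. Compound 3 stands level with the other two: a 1.2-fold higher number from compound 2 to compound 3 (0.06 log units; within the scatter) and a 1.2-fold higher number from compound 1 to compound 3 (0.08 log units; within the scatter) both lie within the scatter. Compound 4 `CNC(=O)c1ccc(-c2ccc(Cl)cc2)c(COc2ccc(-c3nc4cc(C(=O)O)ccc4n3C3CCCCC3)cc2)c1` has methylcarbamoyl in place of dimethylamino on an aromatic carbon, para to a 4-chlorophenyl group: methylcarbamoyl in place of dimethylamino on an aromatic carbon. Two other measured steps change the group at this place. One is a 1.0-fold higher number from compound 1 to compound 2 (0.02 log units; within the scatter), and the other is a 1.2-fold higher number from compound 1 to compound 3 (0.08 log units; within the scatter). Within the data shown here, both are within the scatter, although no methylcarbamoyl compound has been measured yet. The expected change is a 1.1-fold lower number from compound 3 to compound 4 (0.05 log units; within the scatter), so no step beyond the scatter is expected in this assay. For compound 4 the estimated value is 27000 nM, with an expected range from 15000 nM to 50000 nM.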

Compound 4, half-maximal cytotoxic concentration: 25000 nM
Compound 4: the middle estimate sits 1.1-fold (0.03 log units) above what was measured, and the stated range covers the measured number.
By their numbers in this assay, from the lowest: compounds 1, 4, 2 and 3 (each within the scatter of the next).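

Methylcarbamoyl is the only group here with a hydrogen-bond donor at this place, yet in this assay it makes no step beyond the scatter against dimethylamino (a 1.2-fold lower number from compound 3 to compound 4 (0.08 log units; within the scatter)), dimethylsulfamoyl (a 1.0-fold lower number from compound 2 to compound 4 (0.02 log units; within the scatter)) or hydrogen (no change at the digits printed from compound 1 to compound 4 (within the scatter)). This place, para to a 4-chlorophenyl group, has now carried hydrogen and three different groups, with every step among them within the scatter. Nothing available explains this result.

Still open, on these data alone, is whether a carboxylic acid or a longer chain on this aromatic carbon would also stay within the scatter of these numbers.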